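A Pyrimidine Swap at the Far End of a Weak Series

This account rests on a few compounds, and the source may have more. Where it says the series, first, only, none or still open, it means among the compounds named here.

Compound 1, `CC(C)[C@H](NC(=O)COc1cccc2ccccc12)C(=O)N[C@@H](CC(=O)O)C(=O)CSc1nccn1C`, is tested in a functional assay on Jurkat cells (Homo sapiens) for inhibition; a higher number here means a weaker inhibitor, a lower number a stronger inhibitor. In this assay compound 1 stops at a limit, giving > 200000 nM. Two relatives share its core. Compound 2, `CC(C)[C@H](NC(=O)COc1cccc2ccccc12)C(=O)N[C@@H](CC(=O)O)C(=O)CSc1nnnn1-c1ccccc1`, gives 153000 nM in this assay. Compound 3, `CC(C)[C@H](NC(=O)COc1cccc2ccccc12)C(=O)N[C@@H](CC(=O)O)C(=O)COc1nccc(C(F)(F)F)n1`, also stops at a limit in this assay, with > 200000 nM. Both compound 1 and compound 3 thus sit at the limit of > 200000 nM in this assay, at which 2 of the 3 values shown sit. The change from compound 1 to compound 2 is an at least 1.3-fold lower number from compound 1 to compound 2 (0.11 log units; that floor lies within the scatter). The step from compound 2 to compound 3 is an at least 1.3-fold higher number from compound 2 to compound 3 (0.11 log units; that floor lies within the scatter), and the step from compound 1 to compound 3 is a step that the two limits leave unreadable from compound 1 to compound 3. Compound 4, `CC(C)[C@H](NC(=O)COc1cccc2ccccc12)C(=O)N[C@@H](CC(=O)O)C(=O)CSc1nccc(C(F)(F)F)n1`, differs from compound 1 as follows: 4-(trifluoromethyl)pyrimidin-2-yl in place of 1-methyl-1H-imidazol-2-yl on a sulfur. Because the move to the same pyrimidinyl group on an oxygen was a step that the two limits leave unreadable from compound 1 to compound 3, compound 4 is expected to stay weak in this assay, and the expected step is a step that the limit leaves unreadable from compound 1 to compound 4. The estimate for compound 4 is 250000 nM, within 100000 nM to 600000 nM.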

Compound 4, half-maximal inhibitory concentration: > 200000 nM
Compound 4: no number, only a limit; the forecaster's own chance of this, stated with the estimate: 70%; the middle value does not contradict the limit.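

Compound 4 stops at a limit, like compound 1 and compound 3: the limit of > 200000 nM in this assay, at which 3 of the 4 values shown sit. The 4-(trifluoromethyl)pyrimidin-2-yl group therefore gives no readable number on a sulfur, just as it gave none on an oxygen in compound 3, and the steps to compound 4 from compound 1 and from compound 3 cannot be read, with a limit at both ends of each. Going by these compounds alone, the only readable step is an at least 1.3-fold higher number from compound 2 to compound 4 (0.11 log units; that floor lies within the scatter), so this change shows no firm loss against the 1-phenyl-1H-tetrazol-5-yl group.

Going by these compounds, the true strength of compound 1, compound 3 and compound 4 remains open. Also open, on these data alone, is whether an amine on the saturated chain carbon bound to a carbonyl carbon, in place of the sulfanyl group, would give a readable number in this assay.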